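The compounds below may be only part of what the source reports. "The series", "measured", "known", "first", "only" and "open" are said of these compounds alone.

In a functional assay on HeLa cells (Homo sapiens) for antiproliferative activity, read by sulforhodamine B assay, with a stated time of 48 h (a lower number here means a stronger inhibitor of growth, a higher number a weaker inhibitor of growth), compound 1 (`Cc1cc2c(cc1C)C(Cl)=C(c1nnc(S)n1-c1ccccc1)CCC2`) gives 1160 nM and compound 2 (`S=c1[nH]nc(C2=C(Cl)c3ccccc3CCC2)o1`) gives 981 nM as its number, two values that lie close together. Compound 3 (`Cc1cc2c(cc1C)C(Cl)=C(c1nnc(-c3ccccc3)o1)CCC2`), with 4680 nM as its number, stands highest of the three. It lies beyond the scatter from both of the others, which makes it the weakest inhibitor of growth in this small set. Compound 4 (`Cc1cc2c(cc1C)C(Cl)=C(c1nnc(-c3cccc(C(F)(F)F)c3)o1)CCC2`) differs from compound 3 by trifluoromethyl in place of hydrogen on an aromatic carbon, on a six-membered aromatic ring of carbon only, meta to a large group. Within the data shown here, no pair of measured compounds shows this change alone, so the data give no direct guide to its size. A small move towards a lower number is therefore expected, probably not beyond the scatter. The estimated step of a 1.5-fold lower number from compound 3 to compound 4 (0.17 log units; within the scatter) is of that modest kind. For compound 4 the estimated value is 3200 nM with an expected range from 1200 nM to 9000 nM as its likely span.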

Compound 4, concentration for 50% growth inhibition: 1570 nM
Estimate against measurement, compound 4: 2.0-fold (0.31 log units) above, within the range that was stated.
By their numbers in this assay, from the lowest: compounds 2, 1 and 4 (each within the scatter of the next); then compound 3.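

In this assay, among these compounds, trifluoromethyl in place of hydrogen on an aromatic carbon, meta to a large group, gives a 3.0-fold lower number from compound 3 to compound 4 (0.47 log units; beyond the scatter) and is the first change in this set seen on its own. Among the compounds shown here, it shows that this place on the six-membered aromatic ring responds to substitution, since a group of four heavy atoms moves the number beyond the scatter, something the earlier compounds, which differ in more than one place, could not show. No measurement bearing on the reason for this step is available.

The compounds shown leave open whether the step is particular to trifluoromethyl or would also appear with a chlorine atom, a methoxy group or an amine at this place. They also leave open whether trifluoromethyl would give a similar step elsewhere on this ring.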